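A few compounds are considered here, and "the series" means these few. Any claim that something is new, unique, unknown or untested is made for them only; others in the source may bear on it.

In a functional assay on H520 cells (Homo sapiens) for antiproliferative activity (a higher number here means a weaker inhibitor, a lower number a stronger inhibitor), compound 1 (`O=C(CCCCC[C@H](NC(=O)c1ccc(Br)cc1)C(=O)Nc1ccc(-c2ccccc2)cc1)NO`) gives 117 nM and compound 2 (`O=C(/C=C/c1ccccc1)N[C@@H](CCCCCC(=O)NO)C(=O)Nc1cccc2cccnc12`) gives 27 nM, the lower of the two numbers by a gap beyond the scatter. Compound 3 (`CC(C)COC(=O)N[C@@H](CCCCCC(=O)NO)C(=O)Nc1cccc2cccnc12`) differs from compound 2 by isobutoxy in place of 2-phenylethenyl on a carbonyl carbon. For the measured compounds named here, no measured pair tests this change directly. Starting from compound 2 at 27 nM, a moderately higher number is expected, meaning a somewhat weaker inhibitor. The expected size of the change is a 2.2-fold higher number from compound 2 to compound 3 (0.35 log units; beyond the scatter). The estimated value for compound 3 is 60 nM, with an expected range of 20 nM to 180 nM.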

Compound 3, half-maximal inhibitory concentration: 129 nM
For compound 3 the middle estimate is 2.2-fold (0.33 log units) below the measured one, within the range that was stated.
By their numbers in this assay, from the lowest: compound 2; then compounds 1 and 3 (each within the scatter of the next).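

In this assay, for the compounds shown here, placing isobutoxy instead of 2-phenylethenyl on the carbonyl carbon gives a 4.8-fold higher number from compound 2 to compound 3 (0.68 log units; beyond the scatter) and is the first single-place change seen here, showing that the group at this position affects the number. This swap removes the six-membered aromatic ring and the double bond and adds a hydrogen-bond acceptor. Nothing available explains the step.

Which of these differences matters remains open. A benzyloxy or 2-phenylethyl group on the same carbonyl carbon would help separate the ring from the double bond and the oxygen.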